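The compounds below may be only part of what the source reports. "The series", "measured", "known", "first", "only" and "open" are said of these compounds alone.

Measured in an in vitro ADME assay on microsomes from liver (Homo sapiens) for metabolic stability, using NADPH; a higher number here means faster removal of the compound, a lower number slower removal:

Compound 1 `COc1ccc(Br)cc1Cn1c(C(=O)NCC(C)(C)CO)cc2cc(C#N)ccc21`: 104 mL.min-1.g-1
Compound 2 `Cc1ccc(C(F)(F)F)cc1Cn1c(C(=O)NCC(C)(C)CO)cc2cc(C#N)ccc21`: 180 mL.min-1.g-1

Among the measured compounds shown here, compound 2, at 180 mL.min-1.g-1, lies within the scatter of compound 1, at 104 mL.min-1.g-1, the only other measured compound. Compound 3 `Cc1ccc(C)c(Cn2c(C(=O)NCC(C)(C)CO)cc3cc(C#N)ccc32)c1` has methyl in place of trifluoromethyl on an aromatic carbon, (methyl in place of trifluoromethyl on an aromatic carbon). For the measured compounds named here, no measured pair of compounds differs in one place, so the data offer no direct precedent for this change. No step beyond the scatter is expected in this assay. The estimated 1.2-fold lower number from compound 2 to compound 3 (0.08 log units; within the scatter) stays within that scatter. The estimated value for compound 3 is 150 mL.min-1.g-1, with an expected range from 70 mL.min-1.g-1 to 320 mL.min-1.g-1.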

Compound 3, intrinsic clearance in microsomes: 257 mL.min-1.g-1
Beside the measured number, compound 3's estimate is 1.7-fold (0.23 log units) below it; the range from low to high includes it.
By their numbers in this assay, from the lowest: compounds 1, 2 and 3 (each within the scatter of the next, the first and the last beyond it).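

In this assay, among the compounds shown here, methyl in place of trifluoromethyl on this aromatic carbon gives a 1.4-fold higher number from compound 2 to compound 3 (0.15 log units; within the scatter), so this exchange at this position does not separate the two compounds. 2,5-Dimethylphenyl in place of 5-bromo-2-methoxyphenyl gives a 2.5-fold higher number from compound 1 to compound 3 (0.39 log units; beyond the scatter), the only step here beyond the scatter, and a modest one. Nothing available accounts for either step. The compounds shown leave open whether an amine or a carboxylic acid on this aromatic carbon would give a step beyond the scatter in this assay.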